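The source may hold more compounds than are shown below. What is called first, only, known or untested is meant among the compounds shown, and "the series" means these compounds.

Of the compounds shown here, three have so far been measured in a functional assay on CHO cells for agonist activity at Alpha-1A adrenergic receptor (Homo sapiens), read by FLIPR and calcium flux; a lower number here means a smaller maximal response, a higher number a larger maximal response. Compound 1 `c1cc(-c2ccn[nH]2)c2c(c1)C(c1ncc[nH]1)CC2` gives 83%. Compound 2 `CCS(=O)(=O)Nc1cccc(Cc2c[nH]cn2)c1` gives 96%, and compound 3 `CS(=O)(=O)Nc1c(Cl)ccc2c1CCCC2c1ncc[nH]1` gives 61%. On these numbers compound 1 stands second highest of the three: compound 2 lies above it by a gap beyond the usual scatter, and compound 3 lies below it by a larger gap, also beyond the scatter. No two of these measured compounds differ in only one place, so none of the gaps can be tied to a single structural change.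

Compound 4 `Cc1oncc1-c1cccc2c1CCC2c1ncc[nH]1` has not yet been measured. It differs from compound 1 in one place: 5-methyl-1,2-oxazol-4-yl in place of 1H-pyrazol-5-yl on an aromatic carbon. The group that leaves brings a hydrogen-bond donor, the group that enters brings none, in the words of that comparison. Within the data shown here, nothing among the measured compounds shows how such a swap plays out, so the step is expected to be small, more likely downward than upward, and it may well stay within the scatter. Compound 4 is therefore expected to give about 76%, within a range from 52% to 96%. That estimate amounts to an expected step of a number 7 percentage points lower from compound 1 to compound 4 (within the scatter).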

Compound 4, largest response reached (Emax), in percent of the reference or control that the assay uses: 63%
Beside the measured number, compound 4's estimate is 13 percentage points above it; measured number inside the range.
By their numbers in this assay, from the lowest: compounds 3 and 4 (each within the scatter of the next); then compound 1; then compound 2.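

Among these compounds, this is the first step in this assay that can be tied to a single change: 5-methyl-1,2-oxazol-4-yl in place of 1H-pyrazol-5-yl on an aromatic carbon gives a step of a number 20 percentage points lower from compound 1 to compound 4 (beyond the scatter). The maximal response is therefore sensitive to which five-membered aromatic ring sits at this position of the shared core. The entering group differs in its hetero atoms, its methyl and its lack of a hydrogen-bond donor, and nothing measured here says which of these matters.

On these data alone, this single pair cannot separate those differences, so the role of the methyl and of the donor stays open. A 1,2-oxazol-4-yl group without the methyl, or a simple amine on the same aromatic carbon, would help to tell them apart.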